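Butyl to allyl: a small exchange on compound 2

The source may report more compounds than this note shows. Statements on the series, on what has been measured and on what is new or still open speak of the compounds shown alone.

In a functional assay on P388 cells (Mus musculus) for cytotoxicity (on this read-out lower numbers stand for stronger inhibition and higher numbers for weaker inhibition), compound 1 (`C[C@@H]1NC(=O)[C@@H](C)NC(=O)[C@@H]2Cc3ccc(O)c(c3)Oc3ccc(cc3)C[C@@H](C(=O)N2C)N(C)C(=O)[C@H](C)NC(=O)[C@H](Cc2ccccc2)N(C)C1=O`) gives 42.7 nM and compound 2 (`CCCCN1C(=O)[C@@H](C)NC(=O)[C@@H]2Cc3ccc(OC)c(c3)Oc3ccc(cc3)C[C@@H](C(=O)N2C)N(C)C(=O)[C@H](C)NC(=O)[C@H](Cc2ccc(OC)cc2)N(C)C(=O)[C@@H]1C`) gives 12 nM as the lower of the two numbers, a gap that lies beyond the usual scatter. These two compounds differ in more than one place, so the gap cannot be tied to any single change.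

Compound 3 (`C=CCN1C(=O)[C@@H](C)NC(=O)[C@@H]2Cc3ccc(OC)c(c3)Oc3ccc(cc3)C[C@@H](C(=O)N2C)N(C)C(=O)[C@H](C)NC(=O)[C@H](Cc2ccc(OC)cc2)N(C)C(=O)[C@@H]1C`) departs from compound 2 in one place only (vinyl in place of propyl on a saturated chain carbon bound to an amide-type nitrogen in a ring). Cut one bond further out, the same difference reads butyl to allyl. Among the compounds with values here, no measured pair shows what such an exchange does in this assay, so the data offer no direct precedent for it. With compound 2 at 12 nM as the sole close reference, no step beyond the scatter is expected and no direction can be named. For compound 3 the estimate is 14 nM and the expected range runs from 5 nM to 40 nM on this reasoning. The estimate amounts to a 1.2-fold higher number from compound 2 to compound 3 (0.07 log units; within the scatter) and this expected step stays within the scatter.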

Compound 3, half-maximal inhibitory concentration: 18.6 nM
The estimate for compound 3 lay 1.3-fold (0.12 log units) below the measured number, and the stated range covers the measured number.
By their numbers in this assay, from the lowest: compounds 2 and 3 (each within the scatter of the next); then compound 1.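

In this assay, the exchange of butyl for allyl gives a 1.6-fold higher number from compound 2 to compound 3 (0.19 log units; within the scatter), and this is the only comparison among the compounds shown that isolates a single place. It shows that, on a saturated chain carbon bound to an amide-type nitrogen in a ring, vinyl can stand in place of propyl without a step beyond the scatter. At this position, then, a saturated chain end is not required to keep the number close to that of compound 2, and the data give no explanation for this result.

This single exchange does not show how far that holds: a longer chain such as hexyl, a benzyl group, or a chain ending in an amine or a carboxylic acid could behave quite differently at the same place. As far as these compounds go, the gap between compound 1 and compound 2 also remains open, since those two compounds differ in more than one place and none of their differences can yet be read alone.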